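The source may report more compounds than this note shows. Statements on the series, on what has been measured and on what is new or still open speak of the compounds shown alone.

Measured so far in an ADME assay on PBMC cells (Homo sapiens) for cytotoxicity; a higher number here means that more compound is tolerated, a lower number that less compound is tolerated
- compound 1 `CC(CCNC(=O)c1c(Cl)cncc1Cl)N1CCC(C(Oc2ccccn2)c2ccc(C(F)(F)F)cc2)CC1` gives 34100 nM
- compound 2 `CC(CCNC(=O)c1c(Cl)cncc1Cl)N1CCC(C(Oc2cccc(Cl)n2)c2ccc(C(F)(F)F)cc2)CC1` gives > 32500 nM as a limit

Compound 2 stands at the limit of > 32500 nM in this assay, at which 1 of the 2 values shown sits, and that is a limit, not a number.

Compound 3 `CC(CCNC(=O)c1c(Cl)cncc1Cl)N1CCC(C(Oc2ccc(C(F)(F)F)cc2)c2ccc(C(F)(F)F)cc2)CC1` carries a different group on an oxygen on a saturated carbon, with the change counted as 4-(trifluoromethyl)phenyl in place of 6-chloropyridin-2-yl on an oxygen on a saturated carbon here. An aromatic ring with one hetero atom gives way to one of carbon only.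

Among the measured compounds shown here, the one measured step that bears on this is a step that the limit leaves unreadable from compound 1 to compound 2 and it offers no size to carry over. That step, chloro in place of hydrogen on an aromatic carbon, concerns the group that leaves here.

For the measured compounds named here, the only firm number is the one for compound 1 at 34100 nM and the expectation stays anchored there, with a moderate shift toward less compound tolerated allowed.

The expected move is an at least 1.4-fold lower number from compound 2 to compound 3 (0.16 log units; that floor lies within the scatter) as an estimate with wide uncertainty.

Compound 3 is estimated at 22000 nM with an expected range from 9000 nM to 45000 nM in this assay and a report as a limit would not surprise.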

Compound 3, half-maximal cytotoxic concentration: 3100 nM
Compound 3: middle estimate off by 7.1-fold (0.85 log units), on the high side; the whole stated range lies above it.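

In this assay, the group on an oxygen on a saturated carbon turns out to matter: 4-(trifluoromethyl)phenyl in place of pyridin-2-yl gives an 11-fold lower number from compound 1 to compound 3 (1.04 log units; beyond the scatter), and the same group in place of 6-chloropyridin-2-yl gives an at least 10-fold lower number from compound 2 to compound 3 (1.02 log units; beyond the scatter). Compound 2 is held only as a limit, not a number, so the second step has a floor rather than a fixed size: the limit of > 32500 nM in this assay, at which 1 of the 3 values shown sits. The step from compound 1 to compound 2 cannot be read, but across these three compounds the two with a pyridine-type ring of one hetero atom sit high in this assay, while compound 3, with a ring of carbon only, sits clearly lower, and no compound shown goes against this.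

The change removes the ring nitrogen and brings in the trifluoromethyl group together, so the compounds shown do not tell which of the two goes with the lower number. A plain phenyl group, or a pyridin-2-yl group carrying trifluoromethyl, on the same oxygen would separate the two.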